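This account rests on a few compounds, and the source may have more. Where it says the series, first, only, none or still open, it means among the compounds named here.

For the measured compounds named here, in a functional assay on MCF7 cells (Homo sapiens) for inhibition, read by MTT assay, with a stated time of 72 h (a higher number here means a weaker inhibitor, a lower number a stronger inhibitor), compound 1, `COc1cc(NC(C)CCCNC(=O)NNC(=O)Nc2ccc(F)cc2)c2ncccc2c1`, gives 310 nM, the lowest of the three numbers measured so far. Compound 3, `COc1cc(NC(C)CCCNC(=O)Nc2ccc(C(F)(F)F)cc2)c2ncccc2c1`, gives 1900 nM, and compound 2, `COc1cc(NC(C)CCCNC(=O)Nc2cccc(O)c2)c2ncccc2c1`, gives 11000 nM. Compound 4, `COc1cc(NC(C)CCCNC(=O)NNC(=O)Nc2cccc(C(F)(F)F)c2)c2ncccc2c1`, has not yet been measured and differs from compound 1 in one place, on an amide-type nitrogen: 3-(trifluoromethyl)phenyl in place of 4-fluorophenyl on an amide-type nitrogen. There, 3-(trifluoromethyl)phenyl stands in place of 4-fluorophenyl.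

Going by the values given here, no measured step makes this exact exchange. Two steps remove the whole ((4-fluorophenyl)carbamoyl)amino group, which compound 4 does not do in full: a 6.1-fold higher number from compound 1 to compound 3 (0.79 log units; beyond the scatter), a modest step, and a 35-fold higher number from compound 1 to compound 2 (1.55 log units; beyond the scatter), a large one. The closest parallel is the exchange of one substituted phenyl group for another in a 5.8-fold lower number from compound 2 to compound 3 (0.76 log units; beyond the scatter), also modest, which shows that such a swap can move the number in this assay. That step, however, belongs to compounds lacking the longer group, and it gives no direction for compound 4. The change is therefore expected to produce no step beyond the scatter, though a modest one in either direction remains possible. The expected step is a 1.1-fold higher number from compound 1 to compound 4 (0.05 log units; within the scatter). For compound 4, the estimated value is 350 nM, with an expected range from 100 nM to 1200 nM.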

Compound 4, half-maximal inhibitory concentration: 190 nM
Compound 4: middle estimate off by 1.8-fold (0.27 log units), on the high side, and the stated range covers the measured number.
By their numbers in this assay, from the lowest: compounds 4 and 1 (each within the scatter of the next); then compound 3; then compound 2.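

In this assay the exchange at the far end of the longer group gives a 1.6-fold lower number from compound 1 to compound 4 (0.21 log units; within the scatter) and so leaves compound 4 and compound 1 indistinguishable, even though 10 heavy atoms enter where 7 leave. The earlier steps shown here could not show this, since they either removed the whole ((4-fluorophenyl)carbamoyl)amino group, as in a 6.1-fold higher number from compound 1 to compound 3 (0.79 log units; beyond the scatter) and in a 35-fold higher number from compound 1 to compound 2 (1.55 log units; beyond the scatter), or swapped one substituted phenyl for another without that group, as in a 5.8-fold lower number from compound 2 to compound 3 (0.76 log units; beyond the scatter), a step beyond the scatter. Here, on the amide-type nitrogen of the longer group, one substituted phenyl stands in for another with no step beyond the scatter, and no measurement at hand speaks to why the two groups read alike.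

As far as these compounds go, the exchange alters both the substituent and the place it occupies on the phenyl ring, so the two compounds cannot say what either alteration does alone, and the step from compound 3 to a partner carrying the same group on the longer chain remains open. From the compounds shown here alone, it also remains open whether this nitrogen would give a similar number with a phenyl ring carrying an amine or a carboxylic acid.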